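The source may report more compounds than this note shows. Statements on the series, on what has been measured and on what is new or still open speak of the compounds shown alone.

Three measured compounds share a core. In a functional assay on the whole organism (strain NMRI) with Mus musculus as the target, with a stated time of 60 min, at a dose of 5 mg/kg by the intraperitoneal route (a higher number here means a stronger effect of the compound at the dose given, a lower number a weaker effect), compound 1 `CSc1nnc(Cc2ccc(Cl)cc2Oc2ccccc2Cl)[nH]1` gives 125%. Compound 2 `CSc1nnc(Cc2ccc(Cl)cc2Oc2ccccc2F)[nH]1` gives 110% in this assay, and compound 3 `Nc1nnc(Cc2ccccc2Oc2ccccc2)o1` gives 132%. Compound 2 thus stands lowest of the three numbers, with compound 1 nearest to it and compound 3 furthest from it. For the measured compounds named here, the one change measured so far in a single place, fluoro in place of chloro on an aromatic carbon, gave a number 15 percentage points lower from compound 1 to compound 2 (beyond the scatter).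

Compound 4 `CCOc1nnc(Cc2ccc(Cl)cc2Oc2ccccc2F)[nH]1` is not yet measured; it differs from compound 2 by ethoxy in place of methylsulfanyl on an aromatic carbon. Going by the values given here, no measured step touches this part of the molecule: the only step known swaps chloro for fluoro elsewhere, and that step was itself modest, so it offers little guidance for the present change. A step of no change at the digits printed from compound 2 to compound 4 (within the scatter) is expected, that is, nothing clearly beyond the scatter. Compound 4 is therefore estimated at 110% in this assay, within a range from 85% to 135%.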

Compound 4, a percentage reported as activity, at one dose (the size of the read-out at that dose, not a potency): 111%
For compound 4 the middle estimate is 1 percentage points below the measured one; low and high end bracket the measured number.
By their numbers in this assay, from the lowest: compounds 2 and 4 (each within the scatter of the next); then compounds 1 and 3 (each within the scatter of the next).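

In this assay, for the compounds shown here, replacing methylsulfanyl with ethoxy gives a number 1 percentage points higher from compound 2 to compound 4 (within the scatter), the first measured step at this position, on an aromatic carbon between two ring nitrogen atoms. The earlier compounds shown here showed only a chloro-to-fluoro step elsewhere in the molecule, whereas this pair shows that a sulfur-linked group of 2 heavy atoms and an oxygen-linked group of 3 heavy atoms cannot be told apart at this single dose. No measurement shown offers an explanation for this result.

An amine, a carboxylic acid or a longer chain such as butoxy at this position could still behave differently from compound 2 and compound 4. A single dose also leaves open whether these two compounds would separate at other doses.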